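The source may report more compounds than this note shows. Statements on the series, on what has been measured and on what is new or still open speak of the compounds shown alone.

Measured in a functional assay on HepG2 cells (Homo sapiens) for antiproliferative activity, read by MTT assay; on this read-out lower numbers stand for stronger inhibition and higher numbers for weaker inhibition:
Compound 1 `COc1ccc(-c2ccnc(Nc3ccc(Cl)cc3Cl)n2)cc1` gives 190 nM
Compound 2 `Clc1ccc(Nc2nccc(-c3ccc(Br)cc3)n2)c(Cl)c1` gives 720 nM

In this assay compound 2 holds the higher of the two numbers at 720 nM and so marks the weaker end of this pair. Compound 3 (`Cc1ccc(-c2ccnc(Nc3ccc(Cl)cc3Cl)n2)cc1`) keeps the shared core and changes one group, with methyl in place of bromo on an aromatic carbon as 4-bromophenyl becomes 4-methylphenyl.

Within the data shown here, only one measured step bears on this place: a 3.8-fold higher number from compound 1 to compound 2 (0.58 log units; beyond the scatter) with bromo in place of methoxy. Among the measured compounds shown here, no measured compound carries methyl there, so the exchange has no direct reading. The earlier step shows that a single group at this place can shift the number modestly. A small expected move toward a lower number, in the direction of compound 1, is therefore a tentative call, and it may not clear the scatter. The expected change is a 1.9-fold lower number from compound 2 to compound 3 (0.28 log units; within the scatter) and remains only an estimate. For compound 3 the estimated value is 380 nM with an expected range from 130 nM to 1100 nM in this assay.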

Compound 3, half-maximal inhibitory concentration: 344000 nM
The estimate for compound 3 lay 910-fold (2.96 log units) below the measured number; measured number above the stated range.
By their numbers in this assay, from the lowest: compound 1; then compound 2; then compound 3.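

The position on this aromatic ring proved far more sensitive in this assay than the first pair had suggested, with large steps to the 4-methylphenyl compound (a 480-fold higher number from compound 2 to compound 3 (2.68 log units; beyond the scatter)) and (a 1800-fold higher number from compound 1 to compound 3 (3.26 log units; beyond the scatter)), whereas bromo and methoxy had been separated by only a modest step. Bromo and methyl match in heavy-atom count, hydrogen-bond donors, hydrogen-bond acceptors and net charge, so these computed counts do not distinguish compound 2 from compound 3 even though their measured values lie far apart. Nothing available here bears on what lies behind this large step.

The three compounds leave open whether the large rise is particular to methyl or would also appear with an ethyl group, a chloro group or an amine at the same place. As far as these compounds go, whether the same exchange would produce a step of similar size alongside a change elsewhere on the shared core also remains open.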